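The source may report more compounds than this note shows. Statements on the series, on what has been measured and on what is new or still open speak of the compounds shown alone.

In a functional assay on L1210 cells (Mus musculus) for inhibition (on this read-out higher numbers stand for weaker inhibition and lower numbers for stronger inhibition), two compounds have numbers so far:
compound 1 (`CC(C)CN(NC(=O)OCc1ccccc1)C(=O)CN(Cc1ccccc1)NC(=O)Cc1cccc(Br)c1`): 30000 nM
compound 2 (`CC(C)CN(CC(=O)NN(Cc1ccccc1)c1cnccn1)NC(=O)Cc1cccc(Br)c1`): 45000 nM

Compound 1 and compound 2 lie within the usual scatter of each other, so these numbers do not rank them. Both numbers are large on this scale, which means weak inhibition.

Compound 3 (`CC(C)CN(NC(=O)OCc1ccccc1)C(=O)CN(Cc1ccccc1)/N=C/c1ccc(B(O)O)cc1`) has not been measured yet. It comes from compound 1 by a single exchange on an amine nitrogen whose other neighbours are saturated chain carbon, saturated chain carbon: a group of 11 heavy atoms (7 carbon, 1 boron, 1 nitrogen, 2 oxygen; one six-membered aromatic ring of carbon only) in place of a group of 11 heavy atoms (8 carbon, 1 nitrogen, 1 oxygen, 1 bromine; one six-membered aromatic ring of carbon only), on an amine nitrogen. The rest of the structure stays the same.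

Among the measured compounds shown here, no measured pair of compounds shows what this exchange does in this assay and that leaves the expectation loose. For the measured compounds named here, with compound 1 at 30000 nM as the only starting point, no step clearly beyond the scatter is expected, with a slight lean toward stronger inhibition. The estimated change is a 1.5-fold lower number from compound 1 to compound 3 (0.18 log units; within the scatter) and its direction is uncertain. For compound 3 the estimated value is 20000 nM within an expected range from 4000 nM to 70000 nM as a wide band around it.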

Compound 3, half-maximal inhibitory concentration: 14700 nM
For compound 3 the middle estimate is 1.4-fold (0.13 log units) above the measured one, and the stated range covers the measured number.
By their numbers in this assay, from the lowest: compound 3; then compounds 1 and 2 (each within the scatter of the next).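

Among the compounds shown here, on the amine nitrogen whose other neighbours are saturated chain carbon, saturated chain carbon, the group holding bromine can be replaced by the group holding boron without losing inhibition: in this assay the exchange gives a 2.0-fold lower number from compound 1 to compound 3 (0.31 log units; beyond the scatter), a modest gain that is the first step to clear the usual scatter. The gain does not change the overall picture, since compound 3, at 14700 nM, still has a large number on this scale and so remains a weak inhibitor, but it does show that this position can affect the read-out. No measurement shown here explains why the number falls, so the step stands as an observation only.

The exchange alters several things at once, including the loss of bromine, the arrival of boron and a change in the counts of hydrogen-bond donors and acceptors, so a single step cannot show which of these matters. Going by these compounds, it also remains open how a carboxylic acid or an amine on the same aromatic ring would compare with the boron-bearing group at this position.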